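The Benzoyl Ester Step from Compound 1

This account rests on a few compounds, and the source may have more. Where it says the series, first, only, none or still open, it means among the compounds named here.

Compound 1 `Cc1cc(=O)oc2c(CN3CCc4ccccc4C3)c(O)ccc12` is the starting point of this account. In an ADME assay on MT4 cells (Homo sapiens) for cytotoxicity, read by MTT assay, with a stated time of 96 h (a lower number here means that less compound is tolerated, a higher number that more compound is tolerated), compound 1 gives only a limit of the assay, > 100000 nM. Two further compounds from the same study were run in this assay. Compound 2 `CCCCCCCCOc1ccc2c(=O)c(Cc3c(OC(C)=O)ccc4c(C)cc(=O)oc34)c(N(CC)CC)oc2c1` also reaches only the limit, compound 2 sitting at > 100000 nM. Compound 3 `CCC(=O)Oc1ccc2c(C)cc(=O)oc2c1Cc1c(-c2ccccc2)[nH]c2ccccc12` returns a numerical value, compound 3 giving 38000 nM. Compound 1 thus stands at the limit of > 100000 nM in this assay, at which 2 of the 3 values shown sit, so that only a floor for what it is tolerated at is known, and nothing about how far it lies beyond that floor.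

Compound 4 `Cc1cc(=O)oc2c(CN3CCc4ccccc4C3)c(OC(=O)c3ccccc3)ccc12` is the compound not yet measured. It differs from compound 1 in one place: benzoyl in place of hydrogen on an oxygen on an aromatic ring, or read one bond further out, hydroxy to benzoyloxy. Going by the values given here, no step between two measured compounds is available to guide this change. The step from compound 1 to compound 4 is therefore expected to be small, if any, as an at least 1.2-fold lower number from compound 1 to compound 4 (0.09 log units; that floor lies within the scatter), with the result likely staying near the limit. For compound 4 the estimate in this assay is 80000 nM, with a range from 25000 nM to 300000 nM, and a fair chance that only a limit is reported again.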

Compound 4, half-maximal cytotoxic concentration: > 100000 nM
Compound 4: a limit, no number; the forecaster's own chance of this, stated with the estimate: 55%; middle value at least 1.2-fold (0.09 log units) away from the limit.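

In this assay compound 4 gives > 100000 nM as a limit of the assay and not a number. Going by these compounds alone, compound 1 also gives only a limit there, so no step between compound 1 and compound 4 can be read: the limit of > 100000 nM in this assay, at which 3 of the 4 values shown sit. The compounds shown leave open how far beyond their limits compound 1 and compound 4 lie, and so whether hydroxy to benzoyloxy changes what is tolerated at all.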